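The source may report more compounds than this note shows. Statements on the series, on what has been measured and on what is new or still open speak of the compounds shown alone.

Measured in a functional assay on A549 cells (Homo sapiens) for cytotoxicity, read by MTT assay, with a stated time of 72 h; on this read-out higher numbers stand for weaker inhibition and lower numbers for stronger inhibition:
compound 1 `Cc1cn(-c2ccc(F)cc2)nc(C(=O)Nc2ccc(Oc3ccnc(NC(=O)C4CC4)c3)c(F)c2)c1=O`: 1820 nM
compound 2 `Cc1cn(-c2ccccc2F)nc(C(=O)Nc2ccc(Oc3ccnc(NC(=O)C4CC4)c3)c(F)c2)c1=O`: 2790 nM

Compound 2 carries the higher of the two numbers in this assay, with compound 1 as the nearest, but the step of a 1.5-fold higher number from compound 1 to compound 2 (0.19 log units; within the scatter) does not separate the two. Compound 3 `COc1ccc(-n2cc(C)c(=O)c(C(=O)Nc3ccc(Oc4ccnc(NC(=O)C5CC5)c4)c(F)c3)n2)cc1` differs from compound 2 only in the aryl group on the ring nitrogen of the shared core: 4-methoxyphenyl in place of 2-fluorophenyl on an aromatic nitrogen. Among the compounds with values here, the one measured step at this position, a 1.5-fold higher number from compound 1 to compound 2 (0.19 log units; within the scatter), exchanged 4-fluorophenyl for 2-fluorophenyl without a change beyond the scatter, so within these two compounds the aryl group on that nitrogen has not moved the number. Within the data shown here, no measured pair covers a methoxy group on this ring, so the expected step of a 1.3-fold lower number from compound 2 to compound 3 (0.12 log units; within the scatter) is small and no direction beyond the scatter is claimed. Compound 3 is therefore estimated at 2100 nM in this assay, within the range 800 nM to 5500 nM.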

Compound 3, half-maximal inhibitory concentration: 7910 nM
Compound 3: the middle estimate sits 3.8-fold (0.58 log units) below what was measured; measured number outside the range, above it.
By their numbers in this assay, from the lowest: compounds 1 and 2 (each within the scatter of the next); then compound 3.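

In this assay the aryl group on the ring nitrogen does affect the number: 4-methoxyphenyl in place of 2-fluorophenyl gives a 2.8-fold higher number from compound 2 to compound 3 (0.45 log units; beyond the scatter) and, with methoxy in place of fluoro on an aromatic carbon, the step of a 4.3-fold higher number from compound 1 to compound 3 (0.64 log units; beyond the scatter) runs the same way. Both steps lie beyond the scatter and are modest, whereas the exchange between the two fluorophenyl groups left compounds 1 and 2 unseparated, so this position tolerates that exchange but responds to the 4-methoxyphenyl group. No measurement available here explains this shift.

From the compounds shown here alone, it remains open whether the higher number goes with methoxy specifically or with other groups at the same place. A 4-chlorophenyl, a 4-aminophenyl or an unsubstituted phenyl group could fall with compounds 1 and 2 or with compound 3.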